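Notes on the step from compound 3 to compound 4

The compounds below may be only part of what the source reports. "The series", "measured", "known", "first", "only" and "open" are said of these compounds alone.

Values in a functional assay on SGC-7901 cells (Homo sapiens) for antiproliferative activity, read by MTT assay, with a stated time of 24 h; a higher number here means a weaker inhibitor, a lower number a stronger inhibitor:
- compound 1 `Cc1ccccc1NNC(=O)c1ccc(NS(=O)(=O)c2cnc(O)nc2O)cc1` gives > 20000 nM as a limit
- compound 2 `O=C(NNc1ccccc1Cl)c1ccc(NS(=O)(=O)c2cnc(O)nc2O)cc1` gives 3630 nM as a number
- compound 3 `Cc1ccc(C(=O)NNC(=O)c2ccc(NS(=O)(=O)c3cnc(O)nc3O)cc2)cc1` gives > 20000 nM as a limit

Compound 3 stands at > 20000 nM, which is a limit and not a number. This is the limit of > 20000 nM in this assay, at which 2 of the 3 values shown sit.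

Compound 4 `O=C(NNC(=O)c1ccccc1F)c1ccc(NS(=O)(=O)c2cnc(O)nc2O)cc1` carries 2-fluorophenyl in place of 4-methylphenyl on a carbonyl carbon.

Among the compounds with values here, two measured steps bear on this. The step of an at least 5.5-fold lower number from compound 1 to compound 2 (0.74 log units; beyond the scatter) came with chloro in place of methyl on an aromatic carbon, a single pair. The step of an at least 5.5-fold higher number from compound 2 to compound 3 (0.74 log units; beyond the scatter) came with (4-methylphenyl)carbonyl in place of 2-chlorophenyl on an amine nitrogen. The third, a step that the two limits leave unreadable from compound 1 to compound 3, gives no size.

Within the data shown here, no measured pair changes the group on the carbonyl carbon, so the guide is weak. A modest move to a lower number in this assay is expected, by loose analogy with the halogen swap from compound 1 to compound 2. The expected change is an at least 1.6-fold lower number from compound 3 to compound 4 (0.22 log units; that floor lies within the scatter) and may stay unreadable. For compound 4 the estimate is 12000 nM, with an expected range from 3500 nM to 40000 nM.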

Compound 4, half-maximal inhibitory concentration: > 20000 nM
Compound 4 gave a limit, no number; the forecaster's own chance of this, stated with the estimate: 45%; at least 1.6-fold (0.22 log units) between middle value and limit.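

In this assay compound 4 gives > 20000 nM as a limit and not a number, so 2-fluorophenyl on the carbonyl carbon yields no readable value, just as 4-methylphenyl did. The only number shown stays with compound 2, and the series records an at least 5.5-fold higher number from compound 2 to compound 4 (0.74 log units; beyond the scatter) with (2-fluorophenyl)carbonyl in place of 2-chlorophenyl on an amine nitrogen. The steps to compound 4 from compound 1 and compound 3 join two limits and cannot be read, so the change on the carbonyl carbon has no size here, and the set now gathers at one limit: the limit of > 20000 nM in this assay, at which 3 of the 4 values shown sit.

As far as these compounds go, how far compound 3 and compound 4 each lie past that limit stays open. Also open, from the compounds shown here alone, is whether an amine or a carboxylic acid in place of the aromatic group on that carbonyl carbon would give a number.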